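A Methyl Added to Compound 1

The compounds below may be only part of what the source reports. "The series", "measured", "known", "first", "only" and "open" are said of these compounds alone.

Compound 1 `O=C(c1cccnc1)c1ccccc1O`: 31000 nM
Compound 2 `O=C(c1cccnc1)c1cccc(Cl)c1O`: 28000 nM

Among the compounds with values here, in a functional assay on Hep cells (Homo sapiens) for cytotoxicity, read by sulforhodamine B assay, with a stated time of 48 h (a higher number here means a weaker inhibitor, a lower number a stronger inhibitor), compound 1 gives 31000 nM, and compound 2, the only other compound measured, lies within the scatter of it at 28000 nM. Compound 3 `Cc1ccc(O)c(C(=O)c2cccnc2)c1` differs from compound 1 by methyl in place of hydrogen on an aromatic carbon, a methyl para to a hydroxy group. Within the data shown here, the one measured step that bears on this is a 1.1-fold lower number from compound 1 to compound 2 (0.04 log units; within the scatter), which also replaces a hydrogen on an aromatic carbon. A single step is thin evidence, but no change beyond the scatter is expected in this assay. The estimated step is a 1.0-fold lower number from compound 1 to compound 3 (0.01 log units; within the scatter). For compound 3 the expected value is 30000 nM, with an estimated range of 14000 nM to 60000 nM.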

Compound 3, half-maximal inhibitory concentration: 11000 nM
Beside the measured number, compound 3's estimate is 2.7-fold (0.44 log units) above it, and the stated range ends above it.
By their numbers in this assay, from the lowest: compound 3; then compounds 2 and 1 (each within the scatter of the next).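

In this assay, methyl in place of hydrogen, para to a hydroxy group, gives a 2.8-fold lower number from compound 1 to compound 3 (0.45 log units; beyond the scatter) as a modest step. The only earlier step, a 1.1-fold lower number from compound 1 to compound 2 (0.04 log units; within the scatter) with chloro in place of hydrogen, stayed within the scatter, so this is the first change on an aromatic carbon of the core of compound 1 shown to move the number. No measurement shown explains why the methyl has this effect.

From the compounds shown here alone, whether the effect is specific to methyl remains open. How an ethyl, a methoxy or an amine would read at this same position is unknown from the compounds shown.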